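This account rests on a few compounds, and the source may have more. Where it says the series, first, only, none or still open, it means among the compounds named here.

Compound 1 `CCOc1nc(-c2cc3ccccc3o2)cc(-c2ccc(Cl)cc2Cl)c1C#N`: 442000 nM in a functional assay on aorta (strain Wistar) for inhibition, with Thoracic aorta (Rattus norvegicus) as the target; on this read-out lower numbers stand for stronger inhibition and higher numbers for weaker inhibition
Compound 2 `COc1ccc(-c2cc(-c3cc4ccccc4o3)nc(OC)c2C#N)cc1`: 262000 nM in this assay

In this assay compound 2 and compound 1 lie within the usual scatter of each other, so the two cannot be told apart on these numbers. Compound 3 `CCOc1nc(-c2cc3ccccc3o2)cc(-c2ccc(OC)cc2)c1C#N` differs from compound 2 in one place: methyl in place of hydrogen on a saturated chain carbon bound to an oxygen on an aromatic ring. Going by the values given here, no measured pair shows this change alone, so no step beyond the scatter is expected in either direction. The estimate for compound 3 in this assay is 300000 nM, with a range from 120000 nM to 750000 nM. Expected is a 1.1-fold higher number from compound 2 to compound 3 (0.06 log units; within the scatter), a step that stays within the scatter.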

Compound 3, half-maximal inhibitory concentration: 204000 nM
Compound 3: the middle estimate sits 1.5-fold (0.17 log units) above what was measured; low and high end bracket the measured number.
By their numbers in this assay, from the lowest: compounds 3, 2 and 1 (each within the scatter of the next, the first and the last beyond it).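

In this assay, methoxy to ethoxy on a saturated chain carbon bound to an oxygen on an aromatic ring gives a 1.3-fold lower number from compound 2 to compound 3 (0.11 log units; within the scatter), so this position shows no response to the added methyl. Going by these compounds alone, with the ethoxy group held, 4-methoxyphenyl in place of 2,4-dichlorophenyl on an aromatic carbon gives a 2.2-fold lower number from compound 1 to compound 3 (0.34 log units; beyond the scatter), the only step here beyond the scatter, and a modest one. Nothing measured here accounts for either step. From the compounds shown here alone, whether an amine or a longer chain on that oxygen would move the number stays open, as does whether any replacement for the aryl group would bring a larger step.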